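The compounds below may be only part of what the source reports. "The series", "measured", "known", "first", "only" and "open" are said of these compounds alone.

Three compounds share a core and differ only in the group on an aromatic nitrogen. Compound 1 `CC(C)c1ccc(-c2nc(SCc3cn(CC(=O)NC(=O)Nc4ccccn4)nn3)nc(Nc3cccc([N+](=O)[O-])c3)c2C#N)cc1` gives 26400 nM in a functional assay on B16-F10 cells (Mus musculus) for inhibition, read by MTT assay, with a stated time of 72 h; on this read-out higher numbers stand for weaker inhibition and lower numbers for stronger inhibition. Compound 2 `CC(C)c1ccc(-c2nc(SCc3cn(CC(=O)NC(=O)Nc4ccccn4)nn3)nc(Nc3ccccc3F)c2C#N)cc1` gives 8380 nM in this assay, with a 3.2-fold lower number from compound 1 to compound 2 (0.50 log units; beyond the scatter). Compound 3 `CC(C)c1ccc(Nc2nc(SCc3cn(CC(=O)NC(=O)Nc4ccccn4)nn3)nc(-c3ccc(C(C)C)cc3)c2C#N)cc1` gives 4380 nM in this assay; it is set apart from compound 1 by a 6.0-fold lower number from compound 1 to compound 3 (0.78 log units; beyond the scatter), while its gap to compound 2, a 1.9-fold lower number from compound 2 to compound 3 (0.28 log units; within the scatter), is within the scatter.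

Compound 4 `COc1cc(-c2nc(SCc3cn(CC(=O)NC(=O)Nc4ccccn4)nn3)nc(Nc3ccc(C(C)C)cc3)c2C#N)cc(OC)c1OC` is not yet measured. It differs from compound 3 by 3,4,5-trimethoxyphenyl in place of 4-isopropylphenyl on an aromatic carbon. None of the three measured steps touches this position: all of them change the group on the aromatic nitrogen, and the aryl group on the aromatic carbon stays the same throughout. Among the measured compounds shown here, there is therefore no measured step to lean on for this change, and no direction can be read from the data. The working expectation is a number for compound 4 close to that of compound 3, with a step of a 1.1-fold higher number from compound 3 to compound 4 (0.06 log units; within the scatter) expected in this assay. Compound 4 is estimated at 5000 nM, in a range from 1500 nM to 20000 nM.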

Compound 4, half-maximal inhibitory concentration: 1210 nM
The estimate for compound 4 lay 4.1-fold (0.62 log units) above the measured number, outside the stated range (below it).
By their numbers in this assay, from the lowest: compound 4; then compounds 3 and 2 (each within the scatter of the next); then compound 1.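

Among the compounds shown here, until now every change sat on the aromatic nitrogen, so this is the first reading of the aromatic carbon ortho to a cyano group: in this assay, 3,4,5-trimethoxyphenyl in place of 4-isopropylphenyl gives a 3.6-fold lower number from compound 3 to compound 4 (0.56 log units; beyond the scatter). The number therefore responds to the aryl group at this position, yet a single swap cannot separate the loss of the isopropyl group from the gain of the methoxy groups. Nothing available explains the drop.

On these data alone, it remains open whether a phenyl ring with one methoxy group, or a plain phenyl ring, would give a similar number, and how a hydroxyl group or an amine on that ring would compare. Also open, as far as these compounds go, is whether 3,4,5-trimethoxyphenyl would lower the number in the same way with 2-fluorophenyl or 3-nitrophenyl on the aromatic nitrogen.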